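Piperazine ester series: ethyl to methyl step in cytotoxicity

A few compounds are considered here, and "the series" means these few. Any claim that something is new, unique, unknown or untested is made for them only; others in the source may bear on it.

Measured so far in an ADME assay on MDCK cells (Canis lupus familiaris) for cytotoxicity, read by MTT assay, with a stated time of 48 h; on this read-out lower numbers stand for higher toxicity in this test and higher numbers for lower toxicity in this test:

compound 1 `CN1CCN(CCC(=O)O[C@@H]2C[C@@H]3CC[C@@]2(C)C3(C)C)CC1`: 48100 nM
compound 2 `CCN1CCN(CCC(=O)O[C@@H]2C[C@@H]3CC[C@@]2(C)C3(C)C)CC1`: 105000 nM
compound 3 `CCN1CCN(CC(=O)O[C@@H]2C[C@@H]3CC[C@@]2(C)C3(C)C)CC1`: 100000 nM

Compound 3 and compound 2 lie within the scatter of each other in this assay, and compound 3 stands beyond the scatter above compound 1. Among the compounds with values here, the one step in this set with a single structural change runs from compound 2 to compound 1: a 2.2-fold lower number from compound 2 to compound 1 (0.34 log units; beyond the scatter), the change being (hydrogen in place of methyl on a saturated chain carbon bound to an amine nitrogen in a ring). The difference between the core of compound 3 and the core of compound 2 is not broken down here.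

Compound 4 `CN1CCN(CC(=O)O[C@@H]2C[C@@H]3CC[C@@]2(C)C3(C)C)CC1` has not been measured. It differs from compound 3 by hydrogen in place of methyl on a saturated chain carbon bound to an amine nitrogen in a ring, the same change at the same place as between compound 2 and compound 1. A step of similar size is expected from compound 3 to compound 4 in this assay, namely a 2.1-fold lower number from compound 3 to compound 4 (0.33 log units; beyond the scatter), because of a 2.2-fold lower number from compound 2 to compound 1 (0.34 log units; beyond the scatter) on the other core. Compound 4 is therefore expected to give about 47000 nM, estimated to fall between 24000 nM and 95000 nM.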

Compound 4, half-maximal cytotoxic concentration: 103000 nM
The estimate for compound 4 lay 2.2-fold (0.34 log units) below the measured number, and the stated range ends below it.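

In this assay, the ethyl to methyl change on the core of compound 3 gives a 1.0-fold higher number from compound 3 to compound 4 (0.01 log units; within the scatter), which lies within the scatter. Set beside the same change on the core of compound 2, the two steps do not separate: the same change on two cores in this assay, a 2.2-fold lower number (0.34 log units; beyond the scatter) from compound 2 to compound 1 and a 1.0-fold higher number (0.01 log units; within the scatter) from compound 3 to compound 4, 2.2-fold (0.35 log units) apart, within the scatter of two such steps. The pair on the core of compound 2 moves beyond the scatter and the pair on the core of compound 3 does not, but with a single pair per core this shows neither that the change behaves differently on the two cores nor that it carries over as a step of fixed size.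

The compounds shown leave open how a longer chain such as propyl, or a hydroxyethyl group, would read in this assay in the place of ethyl or methyl. They also leave open whether further pairs, on these cores or on one with an amide in place of the ester, would settle the size of the ethyl to methyl step.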